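Replacing methylsulfonyl in compound 3 to give compound 4

The source may hold more compounds than are shown below. What is called first, only, known or untested is meant among the compounds shown, and "the series" means these compounds.

Measured in an ADME assay on MDCK cells (Canis lupus familiaris) for permeability, in the apical to basolateral direction; a higher number here means that the compound crosses the layer faster, a lower number that the compound crosses the layer more slowly:
Compound 1 `CC[S+]([O-])(=NC)c1ccc(Nc2ncc(C(F)(F)F)c(N[C@@H]3CCC[C@H]3N(C)C)n2)cc1`: 7.8 10^-6 cm/s
Compound 2 `CCN=[S+](C)([O-])c1ccc(Nc2ncc(C(F)(F)F)c(N[C@@H]3CCC[C@H]3N(C)C)n2)cc1`: 4.7 10^-6 cm/s; 8.3 10^-6 cm/s; 9.3 10^-6 cm/s (3 entries)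
Compound 3 `CN(C)[C@@H]1CCC[C@H]1Nc1nc(Nc2ccc(S(C)(=O)=O)cc2)ncc1C(F)(F)F`: 9.5 10^-6 cm/s

Compound 3, at 9.5 10^-6 cm/s, stands within the scatter of compound 1. For compound 2 there is no single number, only (the several entries of compound 2 in this assay, 4.7 10^-6 cm/s; 8.3 10^-6 cm/s; 9.3 10^-6 cm/s (3 entries)). Compound 4 `CN(C)[C@@H]1CCC[C@H]1Nc1nc(Nc2ccc([S+](C)(=N)[O-])cc2)ncc1C(F)(F)F` differs from compound 3 by one change: a group of 4 heavy atoms (1 carbon, 1 nitrogen, 1 oxygen, 1 sulfur; no ring) in place of a group of 4 heavy atoms (1 carbon, 2 oxygen, 1 sulfur; no ring), on an aromatic carbon. For the measured compounds named here, the one measured step at such an aromatic carbon is a 1.2-fold higher number from compound 1 to compound 3 (0.09 log units; within the scatter), so no step beyond the scatter is expected in this assay. The expected change is a 1.4-fold lower number from compound 3 to compound 4 (0.13 log units; within the scatter). Compound 4 is estimated at 7 10^-6 cm/s, with an expected range of 3.5 10^-6 cm/s to 13 10^-6 cm/s.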

Compound 4, apparent permeability: 1 10^-6 cm/s
Compound 4: middle estimate off by 7.0-fold (0.85 log units), on the high side; measured number below the stated range.
By their numbers in this assay, from the lowest: compound 4; then compounds 1 and 3 (each within the scatter of the next).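

The position para to a large group now proves sensitive in this assay: the earlier change there gave only a 1.2-fold higher number from compound 1 to compound 3 (0.09 log units; within the scatter), whereas the new group gives a 9.5-fold lower number from compound 3 to compound 4 (0.98 log units; beyond the scatter) and a 7.8-fold lower number from compound 1 to compound 4 (0.89 log units; beyond the scatter). Methylsulfonyl and its replacement have the same heavy-atom count, but the replacement has 1 hydrogen-bond donor and methylsulfonyl has 0. Nothing measured here explains the fall. Going by these compounds, whether that donor matters remains open. A primary sulfonamide or an amine at this position would show whether other groups carrying such a hydrogen give similarly low numbers.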